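Bromo on the phenyl of a dithiocarbamate indole

This account rests on a few compounds, and the source may have more. Where it says the series, first, only, none or still open, it means among the compounds named here.

Measured compounds:
compound 1 `Cc1onc(-c2c(F)cccc2Cl)c1C(=O)Nc1c(-c2ccccc2)[nH]c2ccccc12`, 15000 nM
compound 2 `CCN(CC)C(=S)Sc1c(-c2ccccc2)[nH]c2ccc(Br)cc12`, 26000 nM

In a functional assay on Hs 683 cells (Homo sapiens) for inhibition, read by MTT assay, with a stated time of 72 h (on this read-out higher numbers stand for weaker inhibition of growth and lower numbers for stronger inhibition of growth), compound 1 gives 15000 nM, and compound 2 gives 26000 nM; the two numbers lie within the scatter of each other, so neither stands apart. Compound 3 `CCN(CC)C(=S)Sc1c(-c2ccc(Br)cc2)[nH]c2ccc(Br)cc12` differs from compound 2 in one place: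

bromo in place of hydrogen on an aromatic carbon

Within the data shown here, no measured pair shows this change, so the data give no guide to its size. Compound 3 is expected to stay close to compound 2, with a step of a 1.3-fold lower number from compound 2 to compound 3 (0.11 log units; within the scatter) not clearly beyond the scatter. Compound 3 is estimated at 20000 nM, between 8000 nM and 50000 nM.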

Compound 3, concentration for 50% growth inhibition: 22000 nM
Compound 3: the middle estimate sits 1.1-fold (0.04 log units) below what was measured, within the range that was stated.
By their numbers in this assay, from the lowest: compounds 1, 3 and 2 (each within the scatter of the next).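

Among these compounds, the pair gives a first direct reading of this position on the phenyl ring: in this assay, the change from phenyl to 4-bromophenyl amounts to a 1.2-fold lower number from compound 2 to compound 3 (0.07 log units; within the scatter), so the two compounds cannot be told apart. On this pair, then, bromo on an aromatic carbon para to a large group is tolerated without a clear shift in the read-out. Nothing available bears on why.

On these data alone, what remains open is whether a different group at this place, such as an amine or a carboxylic acid, would give a step beyond the scatter. The compounds shown also leave open whether this result holds with a longer chain in place of the ethyl groups.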